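Pentyl to benzyl on the shared core

The compounds below may be only part of what the source reports. "The series", "measured", "known", "first", "only" and "open" are said of these compounds alone.

In a functional assay on MDA-MB-468 cells (Homo sapiens) for antiproliferative activity, read by MTT assay, with a stated time of 72 h (on this read-out higher numbers stand for weaker inhibition and lower numbers for stronger inhibition), compound 1 `CCCCn1ccnc1-c1cc(OC)c(OC)c(OC)c1` gives 44100 nM, and compound 2 `CCCCCn1ccnc1-c1cc(OC)c(OC)c(OC)c1` gives 57900 nM. Among the measured compounds shown here, compound 2 therefore cannot be told apart from compound 1, the only other compound measured. Compound 3 `COc1cc(-c2nccn2Cc2ccccc2)cc(OC)c1OC` differs from compound 2 as follows: phenyl in place of butyl on a saturated chain carbon bound to an aromatic nitrogen. This is phenyl in place of butyl on a saturated chain carbon bound to an aromatic nitrogen, which can also be read as pentyl to benzyl. For the measured compounds named here, the one measured step that bears on this change is a 1.3-fold higher number from compound 1 to compound 2 (0.12 log units; within the scatter). That step only adds methyl to the chain and brings in no ring, so it is a loose guide. On that evidence, no change beyond the scatter is expected in this assay, and neither direction is favoured. The expected step is a 1.3-fold lower number from compound 2 to compound 3 (0.11 log units; within the scatter). Compound 3 is estimated at 45000 nM, with an expected range of 15000 nM to 100000 nM.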

Compound 3, half-maximal inhibitory concentration: > 100000 nM
Compound 3: only a limit was reported (the forecaster's own chance of this, stated with the estimate: 15%); middle value at least 2.2-fold (0.34 log units) from the limit.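

Compound 3 is reported in this assay only as a limit of the assay, not as a number: the limit of > 100000 nM in this assay, at which 1 of the 3 values shown sits. Even so, the benzyl group on the saturated chain carbon bound to an aromatic nitrogen gives an at least 2.2-fold higher number from compound 1 to compound 3 (0.35 log units; beyond the scatter), so this position can register a change beyond the scatter, which the added methyl of the earlier step did not show. Measured against the pentyl group, the same change gives an at least 1.7-fold higher number from compound 2 to compound 3 (0.23 log units; that floor lies within the scatter), so this comparison alone does not separate the two compounds.

On these data alone, how far compound 3 lies past the limit remains open. Also open, as far as these compounds go, is whether a benzyl group bearing an amine or a carboxylic acid on its ring, or a longer chain ending in phenyl, would return a value within the measurable range.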